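The source may hold more compounds than are shown below. What is called first, only, known or untested is meant among the compounds shown, and "the series" means these compounds.

Compound 3 `O=C(OCc1ccccc1)N(c1ccccc1)C1CN2CCC1CC2` is a carbamate whose shared core carries a benzyl group on the oxygen side. Within the data shown here, in an assay on CHO cells for displacement of a labelled ligand from muscarinic acetylcholine receptor M5 (Homo sapiens), read by scintillation counting, with a stated time of 2 h (on this read-out lower numbers stand for stronger inhibition and higher numbers for weaker inhibition), compound 3 gives 150 nM, the second highest of the three numbers measured so far. Compound 1 `O=C(OCc1ccc(Cl)c(Cl)c1)N(c1ccccc1)C1CN2CCC1CC2` gives 60 nM, and going from it to compound 3 is a step of a 2.5-fold higher number from compound 1 to compound 3 (0.40 log units; beyond the scatter). Compound 2 `COc1ccc(CCCOC(=O)N(c2ccccc2)C2CN3CCC2CC3)cc1OC` gives 1610 nM, the highest of the three. Compound 4 `O=C(OCCCc1ccccc1)N(c1ccccc1)C1CN2CCC1CC2` differs from compound 3 by phenethyl in place of phenyl on a saturated chain carbon bound to an oxygen next to a carbonyl group. Among the measured compounds shown here, no measured step covers exactly this lengthening, but compound 2, which also carries a longer chain, shows a far higher number than compound 3. Compound 4 is therefore expected to give a higher number, a step of a 4.0-fold higher number from compound 3 to compound 4 (0.60 log units; beyond the scatter). The estimate for compound 4 is 600 nM, between 250 nM and 1500 nM.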

Compound 4, inhibition constant: 260 nM
For compound 4 the middle estimate is 2.3-fold (0.36 log units) above the measured one, within the range that was stated.
By their numbers in this assay, from the lowest: compound 1; then compounds 3 and 4 (each within the scatter of the next); then compound 2.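

Lengthening benzyl to 3-phenylpropyl at this position changes little in this assay (a 1.7-fold higher number from compound 3 to compound 4 (0.24 log units; within the scatter)), so chain length alone does not account for the high number of compound 2. Swapping 3,4-dimethoxyphenyl for phenyl on the longer chain counts for far more (a 6.2-fold lower number from compound 2 to compound 4 (0.79 log units; beyond the scatter)), while the longer chain without chlorines stays clearly short of the dichlorinated benzyl compound (a 4.3-fold higher number from compound 1 to compound 4 (0.64 log units; beyond the scatter)). No measurement here offers a reason for these differences.

Still open, from the compounds shown here alone, is how 3,4-dichlorophenyl behaves on the longer chain. Also open, going by these compounds, is whether an even longer chain, or an amine on it, would hold this level.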